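A few compounds are considered here, and "the series" means these few. Any claim that something is new, unique, unknown or untested is made for them only; others in the source may bear on it.

Three compounds share one core and differ only in the group carried on a nitrogen on an aromatic ring. In a functional assay on KB cells (Homo sapiens) for cytotoxicity, read by MTT assay, with a stated time of 3 days (on this read-out lower numbers stand for stronger inhibition and higher numbers for weaker inhibition), compound 1 `N#Cc1c(Nc2ccccc2)nc(SCc2nc3ccccc3[nH]2)nc1-c1ccccc1` gives 2.9 nM, the lowest of the three numbers, though compound 2 `N#Cc1c(NC(N)=S)nc(SCc2nc3ccccc3[nH]2)nc1-c1ccccc1` with 3.2 nM sits a 1.1-fold higher number from compound 1 to compound 2 (0.04 log units; within the scatter). Compound 3 `N#Cc1c(NC(N)=O)nc(SCc2nc3ccccc3[nH]2)nc1-c1ccccc1` gives 9.6 nM, which is a 3.3-fold higher number from compound 1 to compound 3 (0.52 log units; beyond the scatter) and a 3.0-fold higher number from compound 2 to compound 3 (0.48 log units; beyond the scatter).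

Compound 4 `CN1CCN(c2nc(SCc3nc4ccccc4[nH]3)nc(-c3ccccc3)c2C#N)CC1` changes the same position: 4-methylpiperazin-1-yl in place of anilino on an aromatic carbon. The two measured steps away from the anilino group both bear on this, and neither moved the number far. Among the compounds with values here, no measured step swaps the anilino nitrogen for a ring amine, so the size is uncertain, but a modest weakening is expected, a 2.8-fold higher number from compound 1 to compound 4 (0.44 log units; beyond the scatter). Compound 4 is estimated at 8 nM, within 2.5 nM to 30 nM.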

Compound 4, half-maximal inhibitory concentration: 2.7 nM
Compound 4: middle estimate off by 3.0-fold (0.47 log units), on the high side; the range from low to high includes it.
By their numbers in this assay, from the lowest: compounds 4, 1 and 2 (each within the scatter of the next); then compound 3.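

In this assay, 4-methylpiperazin-1-yl, a non-aromatic ring with no hydrogen-bond donor, can replace anilino at this position with no change beyond the scatter (a 1.1-fold lower number from compound 1 to compound 4 (0.03 log units; within the scatter)), and the same holds against the thioureido group (a 1.2-fold lower number from compound 2 to compound 4 (0.07 log units; within the scatter)). So neither an aromatic ring nor a hydrogen-bond donor on this carbon is needed for a low number, while the ureido group remains apart (a 3.6-fold lower number from compound 3 to compound 4 (0.55 log units; beyond the scatter)). Nothing measured here accounts for this tolerance. Going by these compounds, whether morpholin-4-yl, dimethylamino or piperazine lacking the methyl group would also keep the number low remains open.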